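Cytotoxicity notes: phthalide series, step to cyclohexylmethoxy

The source may hold more compounds than are shown below. What is called first, only, known or untested is meant among the compounds shown, and "the series" means these compounds.

Measured so far:
compound 1 `O=C1OC(Cc2nc(-c3ccc(-c4ccccc4)cc3)no2)c2ccccc21` — > 40000 nM
compound 2 `CCOCCOc1ccc(C(O)C2OC(=O)c3c(OC)cc(OC)cc32)cc1` — > 40000 nM

In an ADME assay on RAW264.7 cells (Mus musculus) for cytotoxicity, read by MTT assay, with a stated time of 24 h, in the presence of a further agent that is not named here (a higher number here means a weaker inhibitor, a lower number a stronger inhibitor), compound 1 reaches only the limit > 40000 nM, not a number. In this assay compound 2 likewise stops at the limit > 40000 nM. Among the compounds with values here, compound 2 thus sits with the other value at the limit of > 40000 nM in this assay, at which 2 of the 2 values shown sit; no measured step separates them. Compound 3 `COc1cc(OC)c2c(c1)C(C(O)c1ccc(OCC3CCCCC3)cc1)OC2=O` differs from compound 2 by cyclohexyl in place of ethoxymethyl on a saturated chain carbon bound to an oxygen on an aromatic ring. With both values only limits, the step that the limit leaves unreadable from compound 2 to compound 3 is expected to stay within the scatter, with no direction to read. Compound 3 is expected to give 60000 nM in this assay, in the range 20000 nM to 150000 nM, most likely again only a limit.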

Compound 3, half-maximal inhibitory concentration: > 40000 nM
Compound 3 ended at the assay's limit; the forecaster's own chance of this, stated with the estimate: 80%; the middle value is on the limit's open side.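

Compound 2 and compound 3 both stop at limits, so no step can be read between them: the limit of > 40000 nM in this assay, at which 3 of the 3 values shown sit.

No compound shown gives a number in this assay, which leaves open whether cyclohexyl in place of ethoxymethyl changes anything there.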